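Halogen swap on the sulfonyl ring: notes toward compound 4

The source may hold more compounds than are shown below. What is called first, only, known or untested is meant among the compounds shown, and "the series" means these compounds.

Measured compounds:
compound 1 `O=C1/C(=C/c2ccncc2)CN(S(=O)(=O)c2ccc(F)cc2)C/C1=C\c1ccccc1F` gives 20300 nM
compound 2 `O=C1/C(=C/c2ccncc2)CN(S(=O)(=O)c2ccc(Cl)cc2)C/C1=C\c1ccccc1F` gives 5300 nM
compound 3 `O=C1/C(=C/c2cccnc2)CN(S(=O)(=O)c2ccc(F)cc2)C/C1=C\c1ccccc1C(F)(F)F` gives 2340 nM

All three were read in a functional assay on HepG2 cells (Homo sapiens) for cytotoxicity, read by MTT assay, with a stated time of 24 h; a lower number here means a stronger inhibitor, a higher number a weaker inhibitor. Compound 1 to compound 2 is one change, (chloro in place of fluoro on an aromatic carbon), and it moved the number by a 3.8-fold lower number from compound 1 to compound 2 (0.58 log units; beyond the scatter). Compound 3 stands lowest of the three measured numbers, and the difference between its core and the core of compound 1 is not broken down here. Compound 4 `O=C1/C(=C/c2cccnc2)CN(S(=O)(=O)c2ccc(Cl)cc2)C/C1=C\c1ccccc1C(F)(F)F` is not yet measured; it differs from compound 3 by chloro in place of fluoro on an aromatic carbon, the same change as from compound 1 to compound 2, at the same place. For compound 4 a step of about a 3.3-fold lower number from compound 3 to compound 4 (0.52 log units; beyond the scatter) in this assay is expected, resting on the size of a 3.8-fold lower number from compound 1 to compound 2 (0.58 log units; beyond the scatter), with a wider allowance since that precedent is a single pair. Compound 4 is therefore estimated at 700 nM, between 250 nM and 2500 nM.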

Compound 4, half-maximal inhibitory concentration: 3620 nM
Compound 4: the middle estimate sits 5.2-fold (0.71 log units) below what was measured; the measured number lies above the stated range.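

In this assay, 4-fluorophenyl to 4-chlorophenyl on the sulfonyl group gives a 1.5-fold higher number from compound 3 to compound 4 (0.19 log units; within the scatter), so this pair cannot be told apart. The same change does not read the same on the two cores: the same change on two cores in this assay, a 3.8-fold lower number (0.58 log units; beyond the scatter) from compound 1 to compound 2 and a 1.5-fold higher number (0.19 log units; within the scatter) from compound 3 to compound 4, 5.9-fold (0.77 log units) apart, beyond the scatter of two such steps

The size of the step therefore does not carry from the core of compound 1 to the core of compound 3, though two pairs set no rule for the series and do not show which difference between the cores matters.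

The compounds shown leave open which part of the core sets the size of the step. Going by these compounds alone, also open is whether bromo or a nitrile at the same place would follow the step to compound 2 or the one to compound 4.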